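This account rests on a few compounds, and the source may have more. Where it says the series, first, only, none or still open, it means among the compounds named here.

Three compounds share one core and differ only in the aromatic ring attached to the carbon with a double bond to nitrogen. Compound 1 `O=[N+]([O-])c1ccc(N/C(=N\O)c2ccccc2)c2nonc12` gives 268 nM in an assay on isolated protein for inhibition of Indoleamine 2,3-dioxygenase 1 (Homo sapiens), read by spectrophotometry, with a stated time of 1 h; on this read-out lower numbers stand for stronger inhibition and higher numbers for weaker inhibition. Compound 2 `O=[N+]([O-])c1ccc(N/C(=N\O)c2ccccc2Cl)c2nonc12` gives 135 nM, and compound 3 `O=[N+]([O-])c1ccc(N/C(=N\O)c2ccccc2Br)c2nonc12` gives 80 nM. The steps are a 2.0-fold lower number from compound 1 to compound 2 (0.30 log units; within the scatter), a 3.4-fold lower number from compound 1 to compound 3 (0.53 log units; beyond the scatter) and a 1.7-fold lower number from compound 2 to compound 3 (0.23 log units; within the scatter). Among the three numbers, compound 2 stands second highest: its nearest neighbour is compound 3, and its furthest is compound 1, both within the scatter of it.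

Compound 4 `O=[N+]([O-])c1ccc(N/C(=N\O)c2cccc(Cl)c2)c2nonc12` is the next step from compound 2, with the change (3-chlorophenyl in place of 2-chlorophenyl on a carbon with a double bond to nitrogen). Within the data shown here, none of the measured steps moves a chloro group from one ring carbon to another; they only compare chloro or bromo with hydrogen at a single place, and those steps were small. Among the measured compounds shown here, no measured pair therefore bears directly on this change, and the expected size of the step in this assay is none beyond the scatter, in either direction. The expected step is a 1.3-fold higher number from compound 2 to compound 4 (0.10 log units; within the scatter). Compound 4 is estimated at 170 nM, with a range from 70 nM to 420 nM.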

Compound 4, half-maximal inhibitory concentration: 184 nM
Compound 4: middle estimate off by 1.1-fold (0.03 log units), on the low side; measured number inside the range.
By their numbers in this assay, from the lowest: compounds 3, 2, 4 and 1 (each within the scatter of the next, the first and the last beyond it).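

In this assay, 3-chlorophenyl in place of 2-chlorophenyl on the carbon with a double bond to nitrogen gives a 1.4-fold higher number from compound 2 to compound 4 (0.13 log units; within the scatter), so these two placements of chloro cannot be told apart here, and chloro in place of hydrogen in the new placement gives a 1.5-fold lower number from compound 1 to compound 4 (0.16 log units; within the scatter), which also stays within the scatter. Among these compounds, the one new step beyond the scatter is a 2.3-fold higher number from compound 3 to compound 4 (0.36 log units; beyond the scatter), but it changes both the halogen and its place on the ring, so it cannot be assigned to either change alone. No measurement shown here accounts for any of these steps.

From the compounds shown here alone, it remains open whether moving bromo around the ring would leave the number as unchanged as moving chloro did, which would help separate the two changes within that last step. Going by these compounds, it is also open how a group other than a halogen on this phenyl ring, such as an amine, a methoxy group or a carboxylic acid, would read in this assay.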